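Phenyl to isopropyl on the compound 1 scaffold

This account rests on a few compounds, and the source may have more. Where it says the series, first, only, none or still open, it means among the compounds named here.

Values measured so far in a functional assay on HCT-116 cells (Homo sapiens) for inhibition, read by fluorescence, with a stated time of 48 h (a higher number here means a weaker inhibitor of growth, a lower number a stronger inhibitor of growth), are:

- compound 1 (`CC(C)(COC(=O)[C@@H](N)c1ccccc1)COC1(c2ccc(Cl)cc2)c2ccccc2C(=O)N1Cc1ccccc1`) gives (44000 nM)
- compound 2 (`N[C@H](C(=O)OCCCOC1(c2ccc(Cl)cc2)c2ccccc2C(=O)N1Cc1ccc(Cl)cc1)c1ccccc1`) gives (45000 nM)

Compound 1 stands level with compound 2, their two values lying within the scatter of each other. Compared with compound 1, compound 3 (`CC(C)[C@H](N)C(=O)OCC(C)(C)COC1(c2ccc(Cl)cc2)c2ccccc2C(=O)N1Cc1ccccc1`) carries isopropyl in place of phenyl on a saturated chain carbon bound to an amine nitrogen and a carbonyl carbon. For the measured compounds named here, no measured pair shows this change, so the data give no size for it. In this assay, the expectation starts from compound 1 (44000 nM), with no clear step expected in either direction. The estimated step (a 1.1-fold higher number from compound 1 to compound 3 (0.06 log units; within the scatter)) is expected to stay within the scatter. For compound 3 the estimated value is (50000 nM), with an expected range of (22000 nM to 100000 nM).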

Compound 3, concentration for 50% growth inhibition: 65000 nM
For compound 3 the middle estimate is 1.3-fold (0.11 log units) below the measured one, within the range that was stated.
By their numbers in this assay, from the lowest: compounds 1, 2 and 3 (each within the scatter of the next).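

On the saturated chain carbon bound to an amine nitrogen and a carbonyl carbon, isopropyl in place of phenyl gives no clear shift on the compound 1 scaffold in this assay (a 1.5-fold higher number from compound 1 to compound 3 (0.17 log units; within the scatter)). For the compounds shown here, at this position, then, the six-membered aromatic ring can be replaced by a group with no ring without a difference that rises above the scatter, which the earlier compounds could not show. No supporting measurement bears on this result.

From the compounds shown here alone, whether this tolerance extends to a much smaller group such as methyl, or to a carboxylic acid on the same carbon, remains open. The compounds shown also leave open whether the amine on this carbon matters, since an acetamide in its place would be needed to test that.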